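Swapping the Benzyl Substituent and Tolerance in Canine Cells

This account rests on a few compounds, and the source may have more. Where it says the series, first, only, none or still open, it means among the compounds named here.

Compound 3 `COC(=O)C[C@H](NC(=O)OC(C)(C)C)C(=O)N(Cc1ccc(C(F)(F)F)cc1)C1(C(=O)NCc2ccccc2)CCN(Cc2ccccc2)CC1` was examined in an ADME assay on MDCK cells (Canis lupus familiaris) for cytotoxicity, read by microscopy, with a stated time of 72 h (a lower number here means that less compound is tolerated, a higher number that more compound is tolerated), where compound 3 gives 84000 nM. It stands level with compound 2 `COC(=O)C[C@H](NC(=O)OC(C)(C)C)C(=O)N(C1CC1)C1(C(=O)NCc2ccccc2)CCN(Cc2ccccc2)CC1`, which gives 84000 nM; together they are the highest of the three numbers, and the step of no change at the digits printed from compound 2 to compound 3 (within the scatter) lies within the scatter. Compound 1 `COC(=O)C[C@H](NC(=O)OC(C)(C)C)C(=O)N(C)C1(C(=O)NCc2ccccc2)CCN(Cc2ccccc2)CC1` gives 20000 nM, and the step of a 4.2-fold higher number from compound 1 to compound 3 (0.62 log units; beyond the scatter) shows how much more is tolerated once 4-(trifluoromethyl)phenyl stands in place of hydrogen on the saturated chain carbon bound to the amide-type nitrogen; the parallel step a 4.2-fold higher number from compound 1 to compound 2 (0.62 log units; beyond the scatter) is of the same size. Compound 4 `COC(=O)C[C@H](NC(=O)OC(C)(C)C)C(=O)N(Cc1ccccc1F)C1(C(=O)NCc2ccccc2)CCN(Cc2ccccc2)CC1` differs from compound 3 in one place: 2-fluorophenyl in place of 4-(trifluoromethyl)phenyl on a saturated chain carbon bound to an amide-type nitrogen. Within the data shown here, no measured step compares one substituted benzyl with another; the nearest evidence is no change at the digits printed from compound 2 to compound 3 (within the scatter), where a cyclopropyl and a 4-(trifluoromethyl)benzyl gave the same number, and a 4.2-fold higher number from compound 1 to compound 3 (0.62 log units; beyond the scatter), which separates the smallest group from the larger ones. On that basis the step of a 1.4-fold lower number from compound 3 to compound 4 (0.15 log units; within the scatter) is expected to stay within the scatter or to fall only modestly. Compound 4 is therefore estimated at 60000 nM, with a range from 20000 nM to 110000 nM.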

Compound 4, minimum cytotoxic concentration: 20000 nM
Compound 4: middle estimate off by 3.0-fold (0.48 log units), on the high side, within the range that was stated.
By their numbers in this assay, from the lowest: compounds 1 and 4 (each within the scatter of the next); then compounds 2 and 3 (each within the scatter of the next).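

In this assay the substituted benzyl groups on the amide-type nitrogen prove not to be interchangeable, since the step of a 4.2-fold lower number from compound 3 to compound 4 (0.62 log units; beyond the scatter) goes with 2-fluorobenzyl in place of 4-(trifluoromethyl)benzyl. The step of a 4.2-fold lower number from compound 2 to compound 4 (0.62 log units; beyond the scatter) is of the same size, so among these compounds a benzyl group on this nitrogen does not by itself go with the higher number. The step of no change at the digits printed from compound 1 to compound 4 (within the scatter) places 2-fluorobenzyl with methyl and so removes the earlier division between the smallest group and the larger ones.

From the compounds shown here alone, whether an unsubstituted benzyl, or a benzyl carrying a methoxy group or a chlorine atom, would stay with compound 1 and compound 4 or with compound 2 and compound 3 remains open in this assay for this position. Nothing at hand explains the difference between the two benzyl groups.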